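From Bromo to Methoxy on One Aromatic Carbon

This account rests on a few compounds, and the source may have more. Where it says the series, first, only, none or still open, it means among the compounds named here.

Of the compounds shown here, three with a shared core have been measured in a functional assay on LoVo cells (Homo sapiens) for inhibition, read by MTT assay, with a stated time of 24 h; a lower number here means a stronger inhibitor, a higher number a weaker inhibitor. Compound 1 `CC1(C)[C@H]2CC[C@]1(C)N(Cc1cn(-c3ccc(C#N)cc3)nn1)C(=O)C2`, with a 4-cyanophenyl group, gives 90 nM. Compound 2 `CC1(C)[C@H]2CC[C@]1(C)N(Cc1cn(-c3ccccc3C#N)nn1)C(=O)C2`, with a 2-cyanophenyl group, gives 140 nM. Compound 3 `CC1(C)[C@H]2CC[C@]1(C)N(Cc1cn(-c3ccc(Br)cc3)nn1)C(=O)C2`, with a 4-bromophenyl group, gives 60 nM. Its standing rests on two steps: a 1.5-fold lower number from compound 1 to compound 3 (0.18 log units; within the scatter), and a 2.3-fold lower number from compound 2 to compound 3 (0.37 log units; beyond the scatter). It therefore cannot be separated from the first compound, but it does stand apart from the second.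

Compound 4 `COc1ccc(-n2cc(CN3C(=O)C[C@@H]4CC[C@@]3(C)C4(C)C)nn2)cc1` has methoxy in place of bromo on an aromatic carbon, para to a large group (methoxy in place of bromo on an aromatic carbon). Going by the values given here, no measured compound carries methoxy, so the closest guide is the earlier exchange at this same place, where compound 3 differs from compound 1 by a 1.5-fold lower number from compound 1 to compound 3 (0.18 log units; within the scatter). A step beyond the scatter is therefore not expected. The estimated change is a 1.3-fold higher number from compound 3 to compound 4 (0.12 log units; within the scatter). For compound 4 the estimated value is 80 nM, with an expected range from 30 nM to 200 nM.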

Compound 4, half-maximal inhibitory concentration: 70 nM
The estimate for compound 4 lay 1.1-fold (0.06 log units) above the measured number, within the range that was stated.
By their numbers in this assay, from the lowest: compounds 3, 4, 1 and 2 (each within the scatter of the next, the first and the last beyond it).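

In this assay, the aromatic carbon para to a large group has now carried three different groups, and methoxy, which brings a hydrogen-bond acceptor that bromo lacks, gives a 1.2-fold higher number from compound 3 to compound 4 (0.07 log units; within the scatter), while methoxy in place of cyano gives a 1.3-fold lower number from compound 1 to compound 4 (0.11 log units; within the scatter). Bromo, cyano and methoxy therefore cannot be told apart at this place, even though they differ in their atoms and in size by heavy-atom count. The step to the 4-methoxyphenyl compound from the 2-cyanophenyl compound is a 2.0-fold lower number from compound 2 to compound 4 (0.30 log units; within the scatter), so compound 4 does not stand apart from compound 2 as compound 3 does, and the data shown give no reason for any of this.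

From the compounds shown here alone, whether an amine, a carboxylic acid or a longer chain would fit this place as well remains open. Among the compounds shown, only the nitrile appears at a second place on the aromatic ring, so whether methoxy or bromo would behave alike there is also unknown.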